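This account rests on a few compounds, and the source may have more. Where it says the series, first, only, none or still open, it means among the compounds named here.

Going by the values given here, compound 2 `O=C(Nc1ccc(Oc2ccncn2)cc1)Nc1cccc(C(F)(F)F)c1` and compound 1 `CNc1cc(Oc2ccc(NC(=O)Nc3cccc(C(F)F)c3)cc2)ncn1` share the same core and differ at two places, so no single step between them is counted. In an assay on isolated protein for inhibition of serine/threonine-protein kinase TNNI3K (Homo sapiens) (on this read-out lower numbers stand for stronger inhibition and higher numbers for weaker inhibition), compound 1 gives 100 nM. In this assay compound 2 gives 160 nM, the higher of the two numbers, yet the gap to compound 1 lies within the scatter, so the two show no order. Compound 3 `COc1cc(Oc2ccc(NC(=O)Nc3cccc(C(F)(F)F)c3)cc2)ncn1` follows from compound 2 by methoxy in place of hydrogen on an aromatic carbon. Among the compounds with values here, with no counted step to lean on, the change from compound 2 to compound 3 is expected to be a 1.6-fold lower number from compound 2 to compound 3 (0.20 log units; within the scatter), toward a lower number but not clearly beyond the scatter. Compound 3 is expected to give about 100 nM, between 40 nM and 250 nM.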

Compound 3, half-maximal inhibitory concentration: 4000 nM
Estimate against measurement, compound 3: 40-fold (1.60 log units) below, and the stated range ends below it.
By their numbers in this assay, from the lowest: compounds 1 and 2 (each within the scatter of the next); then compound 3.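

In this assay, the aromatic carbon next to the ring nitrogen proves sensitive to substitution: going from pyrimidin-4-yl to 6-methoxypyrimidin-4-yl gives a 25-fold higher number from compound 2 to compound 3 (1.40 log units; beyond the scatter), a large step beyond the scatter. An addition of only 2 heavy atoms, with no net charge, is enough to weaken inhibition this far. Nothing measured here accounts for the loss. Going by these compounds alone, whether it is specific to methoxy remains open, since this is the only counted step at this carbon. Going by these compounds, how a fluorine atom, a hydroxyl group or an ethoxy group would read out here also stays unknown.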